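This account rests on a few compounds, and the source may have more. Where it says the series, first, only, none or still open, it means among the compounds named here.

Working notes on the series. Going by the values given here, in an ADME assay on J774.A1 cells (Mus musculus) for inhibition, read by MTT assay, with a stated time of 72 h (on this read-out higher numbers stand for an effect only at larger amounts of compound and lower numbers for an effect already at smaller amounts), compound 1 `CNc1nc(NC2CCCC2)nc2ccccc12` gives 39000 nM, and this is the only number available so far. For compound 2 `CNc1nc(NC(C)C)nc2ccccc12` the entry reads "not determined" (no result reported), so compound 2 has no position on this scale and cannot be ranked against compound 1.

The next structure is compound 3 `CC(C)Nc1nc(NCC2CCCO2)c2ccccc2n1`, and the change from compound 2 is oxolan-2-yl in place of hydrogen on a saturated chain carbon bound to a nitrogen on an aromatic ring. The same difference can be read as methyl to (oxolan-2-yl)methyl.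

Among the compounds with values here, with no number for compound 2, the size of this step cannot be read from the data, and no measured step offers a guide. The only reference level in this assay is compound 1 at 39000 nM, so compound 3 is expected to sit at that level, with no shift in either direction beyond the usual scatter. The uncertainty remains wide with a single reference point. For compound 3 the estimated value is 35000 nM, with an expected range from 12000 nM to 100000 nM.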

Compound 3, half-maximal effective concentration: 46000 nM
Estimate against measurement, compound 3: 1.3-fold (0.12 log units) below; the range from low to high includes it.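

No new step can be read: compound 2 has no number to set against compound 3, and compound 1 differs from compound 3 in more than one place. The compounds shown leave open what oxolan-2-yl in place of hydrogen does to the read-out. No evidence on any cause bears on these results.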